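Ester series on a shared core: the free acid step

The source may report more compounds than this note shows. Statements on the series, on what has been measured and on what is new or still open speak of the compounds shown alone.

Compound 3 `Cc1ccc(C(C)C)c(OC(=O)c2cn(-c3ccccc3)nc2-c2ccncc2)c1` stands at the limit of a functional assay on HeLa cells (Homo sapiens) for cytotoxicity, read by MTT assay, with a stated time of 48 h; on this read-out higher numbers stand for weaker inhibition and lower numbers for stronger inhibition: in this assay compound 3 gives > 100000 nM, which is a limit and not a number. Compound 1 `COc1ccc(OC(=O)c2cn(-c3ccccc3)nc2-c2ccncc2)cc1` likewise gives > 100000 nM, a limit. Compound 2 `CC(C)c1cccc(OC(=O)c2cn(-c3ccccc3)nc2-c2ccncc2)c1` gives > 100000 nM, also a limit. The change to compound 4 `O=C(O)c1cn(-c2ccccc2)nc1-c1ccncc1` is hydrogen in place of 2-isopropyl-5-methylphenyl on an oxygen next to a carbonyl group. The steps a step that the two limits leave unreadable from compound 1 to compound 2, a step that the two limits leave unreadable from compound 1 to compound 3 and a step that the two limits leave unreadable from compound 2 to compound 3 cannot be read because of the limit of > 100000 nM in this assay, at which 3 of the 3 values shown sit. Going by the values given here, no measured step therefore gives a readable size for the step to compound 4, and nothing beyond the scatter is expected in this assay. The step of a number no higher from compound 3 to compound 4 (the limit leaves the size open) is an estimate only. Compound 4 is expected at 100000 nM, between 30000 nM and 300000 nM.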

Compound 4, half-maximal inhibitory concentration: > 100000 nM
Compound 4: only a limit was reported (the forecaster's own chance of this, stated with the estimate: 85%); the middle value lies on the limit itself.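

No step from compound 1, compound 2 or compound 3 to compound 4 can be read in this assay: the limit of > 100000 nM in this assay, at which 4 of the 4 values shown sit.

The compounds shown leave open what size any change on an oxygen next to a carbonyl group has in this assay.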